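Amide aryl variation on the shared core: pyrazinyl to methoxypyridyl

The source may hold more compounds than are shown below. What is called first, only, known or untested is meant among the compounds shown, and "the series" means these compounds.

Compound 2 `O=C(Nc1cnccn1)c1c(O)c2cccnc2n(-c2ccccc2)c1=O` is the higher of the two numbers measured in a functional assay on the whole organism for inhibition, with Rattus norvegicus as the target, read by paw edema, at a dose of 100 mg/kg by the oral route; on this read-out lower numbers stand for less inhibition and higher numbers for more inhibition at the one dose given (going by the name of the read-out): compound 2 gives 29.6%, while compound 1 `Cc1cccc(NC(=O)c2c(O)c3cccnc3n(-c3ccccc3)c2=O)c1` gives 14.2%. Among the measured compounds shown here, the one measured step, a number 15.4 percentage points higher from compound 1 to compound 2 (beyond the scatter), is the only comparison on this amide-type nitrogen and therefore the only one that bears on the next change. Compound 3 `COc1ccc(NC(=O)c2c(O)c3cccnc3n(-c3ccccc3)c2=O)cn1` differs from compound 2 in one place: 6-methoxypyridin-3-yl in place of pyrazin-2-yl on an amide-type nitrogen. For the measured compounds named here, no measured pair shows what a methoxy-bearing pyridyl does here, so the step is unanchored; the one known step says only that a two-heteroatom ring scored modestly above a methylphenyl. A ring carrying one nitrogen and a methoxy group is expected to land between the two measured points, so the step of a number 7.6 percentage points lower from compound 2 to compound 3 (within the scatter) is expected to stay within the scatter. Compound 3 is estimated at 22%, within 8% to 38%.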

Compound 3, a percentage reported as inhibition, in the whole organism at one dose (the size of the read-out at that dose, not a potency): 13.1%
Estimate against measurement, compound 3: 8.9 percentage points above; measured number inside the range.
By their numbers in this assay, from the lowest: compounds 3 and 1 (each within the scatter of the next); then compound 2.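

In this assay the change to 6-methoxypyridin-3-yl on the amide-type nitrogen gives a number 16.5 percentage points lower from compound 2 to compound 3 (beyond the scatter), so a nitrogen-bearing aromatic ring at this place does not by itself keep the number of compound 2. Against 3-methylphenyl, the same group gives a number 1.1 percentage points lower from compound 1 to compound 3 (within the scatter), which leaves these two groups indistinguishable here and pyrazin-2-yl as the only one of the three standing clear of the others. Nothing on hand accounts for the step from pyrazin-2-yl to 6-methoxypyridin-3-yl.

Open, from the compounds shown here alone, is whether the methoxy group or the ring itself separates compound 3 from compound 2; plain pyridin-3-yl on the same nitrogen would split the two. Also open, going by these compounds, is how pyrazin-2-yl behaves when it carries an added group such as an amine or a carboxylic acid.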